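Acylsulfonamide cap variation on the macrocyclic series

This account rests on a few compounds, and the source may have more. Where it says the series, first, only, none or still open, it means among the compounds named here.

Measured so far:
- compound 1 `COc1ccc2c(OCC[C@@H]3NC(=O)N(C)CCCC/C=C\[C@@H]4C[C@@]4(C(=O)NS(=O)(=O)C4(C#N)CC4)NC3=O)cc(-c3nc(C(C)C)cs3)nc2c1Cl` — compound 1 in an ADME assay on cells (Homo sapiens) for activation (a higher number here means that more compound is tolerated, a lower number that less compound is tolerated), gives > 75000 nM, which is a limit of the assay and not a number.
- compound 2 `COc1ccc2c(OCC[C@@H]3NC(=O)N(C)CCCC/C=C\[C@@H]4C[C@@]4(C(=O)NS(=O)(=O)C4(C)CC4)NC3=O)cc(-n3ccc(C(C)C)n3)nc2c1Cl` — compound 2 gives 31000 nM in this assay.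
- compound 3 `COc1ccc2c(OCC[C@@H]3NC(=O)N(C)CCCC/C=C\[C@@H]4C[C@@]4(C(=O)NS(=O)(=O)C4(C)CC4)NC3=O)cc(-n3ccc(C(C)C)n3)nc2c1C` — compound 3 gives 25600 nM in this assay.

Compound 1 thus stands only at a limit in this assay; one of the three values sits there (the limit of > 75000 nM in this assay, at which 1 of the 3 values shown sits). Going by the values given here, the one step measured between neighbours, a 1.2-fold lower number from compound 2 to compound 3 (0.08 log units; within the scatter), concerns the substituent on the core and not the sulfonyl end, so no measured step bears on the change now in question.

Compound 4 `COc1ccc2c(OCC[C@@H]3NC(=O)N(C)CCCC/C=C\[C@@H]4C[C@@]4(C(=O)NS(=O)(=O)N(C)C)NC3=O)cc(-c3nc(C(C)C)cs3)nc2c1Cl` differs from compound 1 in one place: dimethylamino in place of 1-cyanocyclopropyl on a sulfonyl sulfur. Among the compounds with values here, with no comparable step measured, no direction can be drawn from the data, and the change is assumed to leave the read-out near where compound 1 stands. The expected step is a number no higher from compound 1 to compound 4 (the limit leaves the size open). Compound 4 is therefore estimated at 75000 nM in this assay, within 30000 nM to 150000 nM, with a fair chance that only a limit is reported again.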

Compound 4, half-maximal cytotoxic concentration: 47800 nM
For compound 4 the middle estimate is 1.6-fold (0.20 log units) above the measured one; low and high end bracket the measured number.
By their numbers in this assay, from the lowest: compounds 3, 2 and 4 (each within the scatter of the next). At a limit, above all of these: compound 1.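

Dimethylamino in place of 1-cyanocyclopropyl on a sulfonyl sulfur is the first change at this end of the molecule to be read in this assay, and it gives an at least 1.5-fold lower number from compound 1 to compound 4 (0.19 log units; that floor lies within the scatter). With this change, compound 4 gives a measured number, 47800 nM, so this sulfonyl position can carry a group without a ring and still give a value inside the range of the assay. Only a floor can be given for the step, and that floor does not go beyond the scatter, because compound 1 stands at a limit and not at a number: the limit of > 75000 nM in this assay, at which 1 of the 4 values shown sits.

Going by these compounds, whether the true step from compound 1 goes beyond the scatter remains open. Also open, on these data alone, is how a cyclic amine such as pyrrolidin-1-yl on the same sulfonyl sulfur would read, and whether dimethylamino would behave alike on the core of compound 2.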